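A few compounds are considered here, and "the series" means these few. Any claim that something is new, unique, unknown or untested is made for them only; others in the source may bear on it.

Measured so far, in a functional assay on MV4-11 cells (Homo sapiens) for antiproliferative activity, with a stated time of 6 days, tested at 1.56 uM; on this read-out lower numbers stand for a weaker effect and higher numbers for a stronger effect at the one concentration tested:
Compound 1, `CNC(=O)N1CCCc2ccc(NC(=O)c3ccc(-c4ccccc4)cc3)cc21`, gives 19.7%.
Compound 2, `CNC(=O)N1CCCc2ccc(NC(=O)c3cccc(-c4ccn(C)n4)c3)cc21`, gives 70.5%.
Compound 3, `CNC(=O)N1CCCc2ccc(NC(=O)c3cccc(-c4cnn(C)c4)c3)cc21`, gives 71.2%.

Compound 1 stands lowest of the three numbers; its nearest neighbour is compound 2, and both compound 2 and compound 3 lie beyond the scatter above it. Going by the values given here, the one measured step between two compounds differing in a single place, a number 0.7 percentage points higher from compound 2 to compound 3 (within the scatter), exchanges one methylpyrazolyl for another and is within the scatter.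

Compound 4, `CNC(=O)N1CCCc2ccc(NC(=O)c3ccc(-c4ccn(S(C)(=O)=O)n4)cc3)cc21`, is not yet measured. It differs from compound 1 as follows: 1-(methylsulfonyl)-1H-pyrazol-3-yl in place of phenyl on an aromatic carbon. Among the compounds with values here, no measured step exchanges phenyl for a pyrazolyl group, and no measured compound carries a methylsulfonyl on the pyrazole, so the step from 2 to 3 does not bear directly on this change. Within the data shown here, what is known is only that the two compounds bearing a pyrazolyl on the benzamide, compound 2 and compound 3, both show far higher inhibition than compound 1. On that basis, for compound 4 the expected step is a number 18.3 percentage points higher from compound 1 to compound 4 (beyond the scatter), a rise beyond the scatter whose size is uncertain. The estimate for compound 4 in this assay is 38%, with a range from 12% to 65%.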

Compound 4, a percentage reported as inhibition, at one concentration (the size of the read-out at that concentration, not a potency): 8.81%
Beside the measured number, compound 4's estimate is 29.2 percentage points above it, outside the stated range (below it).
By their numbers in this assay, from the lowest: compound 4; then compound 1; then compounds 2 and 3 (each within the scatter of the next).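

In this assay, replacing phenyl with 1-(methylsulfonyl)-1H-pyrazol-3-yl on an aromatic carbon, para to a large group, gives a number 10.9 percentage points lower from compound 1 to compound 4 (beyond the scatter), so a five-membered aromatic ring with 2 hetero atoms does not by itself raise inhibition at this place. Both compounds substituted at this place stand low, with compound 1 at 19.7% and compound 4 at 8.81%, while compound 2 and compound 3 differ from compound 4 in more than one place, so their high numbers cannot be carried over to this position. Nothing available explains the fall from phenyl to the methylsulfonyl pyrazole.

As far as these compounds go, this single change exchanges the ring and adds the methylsulfonyl group together, so the share of each in the step remains open; 1-methyl-1H-pyrazol-3-yl at the same place, the group of compound 2, would separate the two. Also open, from the compounds shown here alone, is how an amine or a carboxylic acid carried on the pyrazole at this place would read in this assay, in place of the methylsulfonyl group.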